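This account rests on a few compounds, and the source may have more. Where it says the series, first, only, none or still open, it means among the compounds named here.

Compound 1 `CC(C)CC(=O)N1CCN(c2cc(NCCN)c3ccccc3n2)CC1` and compound 2 `CS(=O)(=O)N1CCN(c2cc(NCCN)c3ccccc3n2)CC1` share one core and differ only at the ring amine nitrogen. In an ADME assay on HEp-2 cells (Homo sapiens) for cytotoxicity, read by CCK-8 assay, with a stated time of 6 days (a higher number here means that more compound is tolerated, a lower number that less compound is tolerated), compound 1 gives no number but only the assay limit > 100000 nM. In this assay compound 2 also gives only the assay limit > 100000 nM. The step that the two limits leave unreadable from compound 1 to compound 2 is unreadable because both values sit at the limit of > 100000 nM in this assay, at which 2 of the 2 values shown sit. Compound 3 `NCCNc1cc(N2CCN(C(=O)C3CCCCC3)CC2)nc2ccccc12` is the next case: cyclohexylcarbonyl in place of methylsulfonyl on an amine nitrogen in a ring. Among the compounds with values here, no measured step bears on this change beyond the two limits. Compound 3 is expected to stay at the limit, with an estimate of 150000 nM and a range from 60000 nM to 400000 nM. The step that the limit leaves unreadable from compound 2 to compound 3 is thus expected to show nothing readable.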

Compound 3, half-maximal cytotoxic concentration: > 100000 nM
Compound 3: only a limit was reported (the forecaster's own chance of this, stated with the estimate: 80%); the middle value is on the limit's open side.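

Compound 3 gives no readable step against compound 1 or compound 2, because all three sit at the limit in this assay: the limit of > 100000 nM in this assay, at which 3 of the 3 values shown sit.

The compounds shown leave open whether any group on the ring amine nitrogen gives a readable half-maximal cytotoxic concentration.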